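This account rests on a few compounds, and the source may have more. Where it says the series, first, only, none or still open, it means among the compounds named here.

Series sharing one core: compound 1 `Cc1ccccc1-c1nc(CN2CCC(C(=O)NCCCN3CCC(C)(C)CC3)CC2)c(C)o1`, compound 2 `Cc1ccccc1-c1nc(CN2CCC(C(=O)NCCCN3CCCCC3)CC2)c(C)o1`, compound 3 `Cc1oc(-c2c(Br)cccc2Br)nc1CN1CCC(C(=O)NCCCN2C[C@H](C)C[C@H](C)C2)CC1`. In an ADME assay on Huh7.5.1 cells (Homo sapiens) for cytotoxicity, read by ATP content, with a stated time of 48 h (a lower number here means that less compound is tolerated, a higher number that more compound is tolerated), compound 1 gives 10200 nM, compound 2 gives 18100 nM and compound 3 gives 6500 nM, the lowest of the three numbers, close to compound 1 and further from compound 2. Among the compounds with values here, the one measured step, a 1.8-fold higher number from compound 1 to compound 2 (0.25 log units; within the scatter), concerns the saturated chain end, not the aryl group. Compound 4 `Cc1cc(C)cc(-c2nc(CN3CCC(C(=O)NCCCN4C[C@H](C)C[C@H](C)C4)CC3)c(C)o2)c1` differs from compound 3 at the aryl group: 3,5-dimethylphenyl in place of 2,6-dibromophenyl on an aromatic carbon. Within the data shown here, no measured step covers an aryl replacement, so the only guide is that the series sits within a narrow band. In this assay the expected step is a 1.2-fold higher number from compound 3 to compound 4 (0.06 log units; within the scatter), an estimate that stays within the scatter. Compound 4 is therefore estimated at 7500 nM, range 3500 nM to 16000 nM.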

Compound 4, half-maximal cytotoxic concentration: 4050 nM
Compound 4: the middle estimate sits 1.9-fold (0.27 log units) above what was measured, and the stated range covers the measured number.
By their numbers in this assay, from the lowest: compounds 4, 3, 1 and 2 (each within the scatter of the next, the first and the last beyond it).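

In this assay, within the data shown here, the aryl exchange gives a 1.6-fold lower number from compound 3 to compound 4 (0.21 log units; within the scatter) and so stays within the scatter, the only measured step at this position. Replacing 2,6-dibromophenyl with 3,5-dimethylphenyl keeps the heavy-atom count of the group, yet it changes both the substituent atoms and their placement on the ring, and this single step cannot separate the two. No available evidence accounts for the result. From the compounds shown here alone, whether 2,6-dimethylphenyl or 3,5-dibromophenyl would fall in the same band remains open, as does the reading for unsubstituted phenyl.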